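Benzyl to isopentyl on a shared core

A few compounds are considered here, and "the series" means these few. Any claim that something is new, unique, unknown or untested is made for them only; others in the source may bear on it.

In an in vitro ADME assay on microsomes from liver (Homo sapiens) for metabolic stability, tested at 1 uM (on this read-out lower numbers stand for a shorter-lived compound and higher numbers for a longer-lived compound), the measured compounds read as follows, each value a limit of the assay:
Compound 1 `CS(=O)(=O)Nc1ccc2c(c1)S(=O)(=O)N=C(C1=C(O)[C@@H]3[C@H]4CC[C@H](C4)[C@@H]3N(Cc3ccccc3)C1=O)N2` gives > 1 h as a limit
Compound 2 `CS(=O)(=O)Nc1ccc2c(c1)S(=O)(=O)N=C(C1=C(O)[C@@H]3[C@H]4CC[C@H](C4)[C@@H]3N(Cc3ccccc3Cl)C1=O)N2` gives > 1 h as a limit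
Compound 3 `CS(=O)(=O)Nc1ccc2c(c1)S(=O)(=O)N=C(C1=C(O)[C@@H]3[C@@H]4CC[C@@H](C4)[C@@H]3N(Cc3ccccc3)C1=O)N2` gives > 1 h as a limit

Compound 3 thus stands with no number of its own, and it shares this position with the other two, as the limit of > 1 h in this assay, at which 3 of the 3 values shown sit, makes plain. Compound 4 `CC(C)CCN1C(=O)C(C2=NS(=O)(=O)c3cc(NS(C)(=O)=O)ccc3N2)=C(O)[C@@H]2[C@@H]3CC[C@@H](C3)[C@@H]21` has not yet been measured. It differs from compound 3 by isobutyl in place of phenyl on a saturated chain carbon bound to an amide-type nitrogen in a ring, and the same difference reads benzyl to isopentyl.

For the measured compounds named here, two measured steps bear on this change, though only loosely. Going by the values given here, the first is a step that the two limits leave unreadable from compound 1 to compound 2, with chloro in place of hydrogen on an aromatic carbon. The second is a step that the two limits leave unreadable from compound 1 to compound 3, which comes with the fact that compounds 1 and 3 differ only in the configuration as drawn and leaves the benzyl group as it is. Neither gives a size, and every measured compound keeps the phenyl ring. No direction can therefore be expected from these steps. The estimated change, a number no higher from compound 3 to compound 4 (the limit leaves the size open), is expected to stay small. For compound 4 the estimated half-life is 1 h, with an expected range from 0.4 h to 2.5 h.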

Compound 4, half-life: 0.3 h
Beside the measured number, compound 4's estimate is 3.3-fold (0.52 log units) above it; measured number outside the range, below it.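

In this assay, for the compounds shown here, the change from benzyl to isopentyl gives an at least 3.3-fold lower number from compound 3 to compound 4 (0.52 log units; beyond the scatter), the only step that can be read. Compound 4 is also the only compound shown without the phenyl ring and the only one with a value that is not a limit, so the group at this place, on a saturated chain carbon bound to an amide-type nitrogen in a ring, can clearly matter for half-life, which the earlier compounds could not show. The earlier steps cannot be read because both compounds in each pair sit at the same limit: the limit of > 1 h in this assay, at which 3 of the 4 values shown sit.

The compounds shown leave open how large the step really is, since compound 3 has only a limit, and whether it follows from losing the phenyl ring or from the isobutyl group that enters in its place. As far as these compounds go, it also remains open whether a cyclohexyl ring, a pyridine ring or a straight butyl chain at this place would give a half-life like that of compound 4, and whether the same change on the core of compound 1 would give a similar step.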